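This account rests on a few compounds, and the source may have more. Where it says the series, first, only, none or still open, it means among the compounds named here.

Compound 2 `Cc1ccc(CNc2ncnc3c2ncn3[C@@H]2O[C@H](CO)[C@@H](O)[C@H]2O)cc1` carries a 4-methylphenyl group. In a functional assay on HL-60 cells (Homo sapiens) for antiproliferative activity, with a stated time of 72 h (a higher number here means a weaker inhibitor, a lower number a stronger inhibitor), compound 2 gives only a limit of the assay, > 166000 nM, so the true value lies somewhere beyond that mark (the limit of > 166000 nM in this assay, at which 1 of the 3 values shown sits). Compound 1 `OC[C@H]1O[C@@H](n2cnc3c(NCc4ccccc4Cl)ncnc32)[C@H](O)[C@@H]1O`, with a 2-chlorophenyl group in the same place, gives 1600 nM in this assay, and the step of an at least 100-fold higher number from compound 1 to compound 2 (2.01 log units; beyond the scatter) shows how sharply the methyl group weakened inhibition. Compound 3 `OC[C@H]1O[C@@H](n2cnc3c(NCc4cc(F)cc(F)c4)ncnc32)C(O)C1O`, with a 3,5-difluorophenyl group, gives 9100 nM. Compound 4 `OC[C@H]1O[C@@H](n2cnc3c(NCc4ccc(F)c(Cl)c4)ncnc32)[C@H](O)[C@@H]1O` differs from compound 2 by 3-chloro-4-fluorophenyl in place of 4-methylphenyl on a saturated chain carbon bound to a nitrogen on an aromatic ring. Because compound 1 gives 1600 nM and compound 3 gives 9100 nM, a large fall in number is expected, the estimated step being an at least 33-fold lower number from compound 2 to compound 4 (1.52 log units; beyond the scatter). For compound 4 the expected value is 5000 nM, within a range from 1000 nM to 30000 nM.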

Compound 4, half-maximal inhibitory concentration: 3500 nM
For compound 4 the middle estimate is 1.4-fold (0.15 log units) above the measured one, and the stated range covers the measured number.
By their numbers in this assay, from the lowest: compound 1; then compound 4; then compound 3. At a limit, above all of these: compound 2.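

The 3-chloro-4-fluorophenyl group restores a measurable number, with an at least 47-fold lower number from compound 2 to compound 4 (1.67 log units; beyond the scatter) on record, so this place does not refuse every substituted phenyl ring. That step has only a lower bound, as compound 2 is a limit of the assay: the limit of > 166000 nM in this assay, at which 1 of the 4 values shown sits. The change from the 2-chlorophenyl group costs far less, and a 2.2-fold higher number from compound 1 to compound 4 (0.34 log units; beyond the scatter) leaves compound 1 the stronger of the two. Still open, on these data alone, is whether the chlorine or the fluorine of compound 4 matters more. Also open, as far as these compounds go, is how an amine, a carboxylic acid or a longer chain would fare here.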